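Lengthening the Hydroxy Chain of Compound 1

The source may report more compounds than this note shows. Statements on the series, on what has been measured and on what is new or still open speak of the compounds shown alone.

In a functional assay, read by fluorescence and spectrophotometry, with a stated time of 1 h (a lower number here means that less compound is needed, a higher number that more compound is needed for the effect), compound 1 `O=S(=O)(/C=C/c1ccc(O)c(O)c1)CCCCCCCO` gives 5900 nM and stands level, within the scatter, with compound 2 `O=S(=O)(/C=C/c1ccc(O)c(O)c1)CCC1CCCC1` at 6800 nM and compound 3 `O=S(=O)(/C=C/c1ccc(O)c(O)c1)CCCC1CCCCC1` at 7900 nM in this small set. Compound 4 `O=S(=O)(/C=C/c1ccc(O)c(O)c1)CCCCCCCCCCCO` has 4-hydroxybutyl in place of hydroxy on a saturated chain carbon, seven bonds along the chain from a sulfonyl sulfur and so carries a longer chain than compound 1. Three measured steps reshape this chain: a 1.2-fold higher number from compound 1 to compound 2 (0.06 log units; within the scatter) and a 1.3-fold higher number from compound 1 to compound 3 (0.13 log units; within the scatter) and a 1.2-fold higher number from compound 2 to compound 3 (0.07 log units; within the scatter) all stay within the scatter. None of them extends the hydroxy chain, so the evidence is indirect. In this assay the expected change is no larger than the scatter, with a 1.0-fold higher number from compound 1 to compound 4 (0.01 log units; within the scatter) as the estimated step. Compound 4 is expected at 6000 nM with an estimated range of 2500 nM to 14000 nM around that value.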

Compound 4, half-maximal effective concentration: 22600 nM
Estimate against measurement, compound 4: 3.8-fold (0.58 log units) below, outside the stated range (above it).
By their numbers in this assay, from the lowest: compounds 1, 2 and 3 (each within the scatter of the next); then compound 4.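

Among the compounds shown here, with 4-hydroxybutyl in place of hydroxy, this assay shows a 3.8-fold higher number from compound 1 to compound 4 (0.58 log units; beyond the scatter) and this is the first step in the set to pass beyond the scatter. The chain therefore does respond to change, which the cyclopentyl and cyclohexyl groups of compounds 2 and 3 gave no sign of. Nothing shown gives a reason for this step.

Open, on these data alone, is whether a chain of in-between length would already raise the number. A plain alkyl chain of the same length, or a carboxylic acid or an amine in place of the hydroxy, could separate the effect of length from that of the end group.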